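This account rests on a few compounds, and the source may have more. Where it says the series, first, only, none or still open, it means among the compounds named here.

Of the compounds shown here, two have so far been measured in an ADME assay for pharmacokinetics, read by LC-MS, in phosphate buffer, with a stated time of 120 min, at pH 7.4, tested at 1 uM, in the presence of a further agent that is not named here; a lower number here means that the compound disappears faster, a higher number that the compound lasts longer. For compound 1 `O=C(/C=C/CC(=O)Nc1ccccc1)Nc1ccccc1` the read-out is a limit of the assay rather than a number, > 8.53 h, which is the limit of > 8.53 h in this assay, at which 1 of the 2 values shown sits. For the measured compounds named here, compound 2 `O=C(/C=C/CN1CCCC1)Nc1ccccc1` gives 2.7 h, the only number so far. Compound 3 `CN(C)C/C=C/C(=O)Nc1ccccc1` is not yet measured and differs from compound 2 by dimethylamino in place of pyrrolidin-1-yl on a saturated chain carbon bound to a double-bonded chain carbon. Going by the values given here, no step between measured compounds that differ in one place is available, so the expected step of a 1.1-fold lower number from compound 2 to compound 3 (0.03 log units; within the scatter) is kept small, within the usual scatter, with no direction favored. Compound 3 is therefore estimated at 2.5 h, expected to fall between 1.2 h and 5.2 h.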

Compound 3, half-life: 1.93 h
The estimate for compound 3 lay 1.3-fold (0.11 log units) above the measured number, and the stated range covers the measured number.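

For the compounds shown here, at the saturated chain carbon bound to a double-bonded chain carbon, this assay now gives a first step for dimethylamino in place of pyrrolidin-1-yl: a 1.4-fold lower number from compound 2 to compound 3 (0.15 log units; within the scatter). With or without the five-membered non-aromatic ring, the two compounds cannot be told apart in this read-out. Nothing measured here bears on the cause of this result. On these data alone, whether piperidine or morpholine at this place would also stay within the scatter remains open. So does whether a primary amine would.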